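Two Chloro Positions on a Benzylsulfanyl Side Chain

The source may report more compounds than this note shows. Statements on the series, on what has been measured and on what is new or still open speak of the compounds shown alone.

Of the compounds shown here, three of a shared core have been tested in a functional assay on the whole organism (artery, strain albino) with Rattus norvegicus as the target, with a stated time of 30 min, at a dose of 10 mg/kg by the oral route; a higher number here means more inhibition at the dose given (going by the name of the read-out), a lower number less inhibition. Compound 1 `CC1=C(C(=O)Nc2ccc([N+](=O)[O-])cc2)C(c2ccc(Br)cc2)N=C(SCc2cccc(Cl)c2)N1` gives 2.6%. Compound 2 `CC1=C(C(=O)Nc2ccc([N+](=O)[O-])cc2)C(c2ccc(Br)cc2)N=C(SCc2ccc(Cl)cc2)N1` differs from compound 1 by 4-chlorophenyl in place of 3-chlorophenyl on a saturated chain carbon bound to a sulfur; in this assay compound 2 gives 6.2%; the step is a number 3.6 percentage points higher from compound 1 to compound 2 (within the scatter). Compound 3 `CC1=C(C(=O)Nc2ccc([N+](=O)[O-])cc2)C(c2cccc([N+](=O)[O-])c2)N=C(SCc2cccc(Cl)c2)N1` carries a different core, set apart from compound 1 by 3-nitrophenyl in place of 4-bromophenyl on a saturated ring carbon; in this assay compound 3 gives 4.1%; the step is a number 1.5 percentage points higher from compound 1 to compound 3 (within the scatter).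

Compound 4 `CC1=C(C(=O)Nc2ccc([N+](=O)[O-])cc2)C(c2cccc([N+](=O)[O-])c2)N=C(SCc2ccc(Cl)cc2)N1` has not yet been measured in this assay. It differs from compound 3 by 4-chlorophenyl in place of 3-chlorophenyl on a saturated chain carbon bound to a sulfur, and the place of this change is worded the same as for the pair of compound 1 and compound 2, so it is the same change made on the other core.

Since that change gave a number 3.6 percentage points higher from compound 1 to compound 2 (within the scatter), and all three numbers sit close together, the expected step is a number 1.9 percentage points higher from compound 3 to compound 4 (within the scatter), resting on compound 3 and its 4.1%. Compound 4 is therefore estimated at 6%, expected to fall between 0% and 14%.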

Compound 4, a percentage reported as inhibition, in the whole organism at one dose (the size of the read-out at that dose, not a potency): 3.1%
Beside the measured number, compound 4's estimate is 2.9 percentage points above it, within the range that was stated.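

On the core of compound 3, 4-chlorophenyl in place of 3-chlorophenyl on a saturated chain carbon bound to a sulfur gives a number 1 percentage points lower from compound 3 to compound 4 (within the scatter) in this assay, and beside the same change on the core of compound 1 it reads: the same change on two cores in this assay, a number 3.6 percentage points higher (within the scatter) from compound 1 to compound 2 and a number 1 percentage points lower (within the scatter) from compound 3 to compound 4, 4.6 percentage points apart, within the scatter of two such steps. The other change, 3-nitrophenyl in place of 4-bromophenyl on a saturated ring carbon, gives a number 3.1 percentage points lower from compound 2 to compound 4 (within the scatter), and it compares with its earlier counterpart in the same way: the same change on two cores in this assay, a number 1.5 percentage points higher (within the scatter) from compound 1 to compound 3 and a number 3.1 percentage points lower (within the scatter) from compound 2 to compound 4, 4.6 percentage points apart, within the scatter of two such steps. This shows that neither change separates the two cores in this series, yet it does not show that either change carries over, since each single step and each gap between steps lies within the scatter and no effect of either change is established on any core.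

All four compounds carry a chlorobenzyl group on the sulfur, so they leave open whether a carboxylic acid, an amine or a longer chain in that place would give a step beyond the scatter in this assay. As far as these compounds go, whether such a step would then carry from one core to the other also remains open.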